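The source may report more compounds than this note shows. Statements on the series, on what has been measured and on what is new or still open speak of the compounds shown alone.

Compound 1 `Cc1noc(C)c1-c1cccc(Oc2ccc(C#N)c(C(F)(F)F)c2)c1` has the entry "not determined" (no result reported) in a functional assay on VCaP cells (Homo sapiens) for antiproliferative activity, read by CCK-8 assay, with a stated time of 6 days (on this read-out higher numbers stand for weaker inhibition and lower numbers for stronger inhibition), so no number is available for it. For the measured compounds named here, compound 2 `CCN(c1ccc(C#N)c(Cl)c1)c1cc(-c2cncnc2)ccc1C` gives 3920 nM in this assay, the only number so far, so nothing sets it in order against any other compound. Compound 3 `CCN(c1ccc(C#N)c(Cl)c1)c1cc(-c2cccnc2)ccc1C` differs from compound 2 in one place: pyridin-3-yl in place of pyrimidin-5-yl on an aromatic carbon. Going by the values given here, no measured pair carries this change, so its size is open; a slight move toward stronger inhibition, probably within the usual scatter, is expected, with an estimated step of a 1.6-fold lower number from compound 2 to compound 3 (0.20 log units; within the scatter). Compound 3 is therefore expected to give 2500 nM in this assay, in the range 1000 nM to 7000 nM.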

Compound 3, half-maximal inhibitory concentration: 1270 nM
Estimate against measurement, compound 3: 2.0-fold (0.29 log units) above, within the range that was stated.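

The change of pyrimidin-5-yl to pyridin-3-yl, on the aromatic carbon para to a methyl group, gives a 3.1-fold lower number from compound 2 to compound 3 (0.49 log units; beyond the scatter) in this assay and lies beyond the scatter. This position therefore responds to a change within the six-membered aromatic ring, even with the heavy-atom count unchanged. Nothing available accounts for the size of this step.

Open, on these data alone, is how an unsubstituted phenyl ring, a morpholine or a carboxylic acid at this position would compare with pyridin-3-yl. For the compounds shown here, the single pair also leaves open whether this step carries over to other cores.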